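The compounds below may be only part of what the source reports. "The series", "measured", "known", "first", "only" and "open" are said of these compounds alone.

Measured so far in a functional assay on HCT-116 cells (Homo sapiens) for cytotoxicity, read by MTT assay, with a stated time of 48 h; a higher number here means a weaker inhibitor of growth, a lower number a stronger inhibitor of growth:
Compound 1 `Clc1cc2nc(-c3ccccc3Cl)[nH]c2cc1Cl`: 23000 nM
Compound 2 `CC(C)n1c(C(F)(F)F)nc2cc(Cl)c(Cl)cc21`: 81900 nM
Compound 3 `FC(F)(F)c1nc2cc(Cl)c(Cl)cc2n1CC1CC1`: 61300 nM

Compound 3, at 61300 nM, lies within the scatter of compound 2, while compound 1 shows a clearly lower number than either. The next compound, compound 4 `Nc1cccc(Cn2c(C(F)(F)F)nc3cc(Cl)c(Cl)cc32)c1`, carries 3-aminophenyl in place of cyclopropyl on a saturated chain carbon bound to an aromatic nitrogen. Among the compounds with values here, only one measured step bears on this part of the structure: a 1.3-fold lower number from compound 2 to compound 3 (0.13 log units; within the scatter), which swapped isopropyl on an aromatic nitrogen for cyclopropylmethyl. Within the data shown here, compound 1 differs from the other two in more than one place, so it offers no single step to compare. Among the measured compounds shown here, the change to compound 4 is larger than the one measured step, and no measured compound shows what an added aromatic ring or amino group does here. The small size of that one step is therefore weak guidance, and no step beyond the scatter is expected in this assay, though the uncertainty is wide in both directions. The estimated change is a 1.2-fold lower number from compound 3 to compound 4 (0.09 log units; within the scatter). The estimate for compound 4 is 50000 nM, with an expected range from 15000 nM to 100000 nM.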

Compound 4, concentration for 50% growth inhibition: 22600 nM
For compound 4 the middle estimate is 2.2-fold (0.34 log units) above the measured one; low and high end bracket the measured number.
By their numbers in this assay, from the lowest: compounds 4 and 1 (each within the scatter of the next); then compounds 3 and 2 (each within the scatter of the next).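

In this assay this position proves able to move the read-out: the earlier change here gave only a 1.3-fold lower number from compound 2 to compound 3 (0.13 log units; within the scatter) and so stayed within the scatter, whereas placing 3-aminophenyl in place of cyclopropyl gives a 2.7-fold lower number from compound 3 to compound 4 (0.43 log units; beyond the scatter) as a modest but real step. The substituent on the saturated chain carbon bound to an aromatic nitrogen is therefore not indifferent to change in this assay, at least when a six-membered aromatic ring of carbon only, carrying a hydrogen-bond donor and acceptor, replaces a three-membered non-aromatic ring. Nothing available explains why this exchange lowers the number.

The aromatic ring and the amino group arrive together in this single change, so the compounds shown cannot tell which of them carries the step, and a plain phenyl group on the same chain carbon would separate the two. Going by these compounds, it also stays open whether an amine is needed at all, or whether a hydroxyl group, a carboxylic acid or a longer chain linking the ring to the aromatic nitrogen would hold or extend the step.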